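The source may hold more compounds than are shown below. What is called first, only, known or untested is meant among the compounds shown, and "the series" means these compounds.

Working notes on the series, read in a functional assay on A-375 cells (Homo sapiens) for antiproliferative activity, read by MTT assay, with a stated time of 72 h; on this read-out lower numbers stand for stronger inhibition and higher numbers for weaker inhibition. Compound 1 (`O=C1COc2ccc(-c3cnc(Cl)c(NS(=O)(=O)c4ccc(F)cc4)c3)cc2N1C1CCCCC1`) stands at > 40000 nM, which is a limit of the assay and not a number. Compound 2 (`COc1ncc(-c2ccc3c(c2)N(C2CCCCC2)C(=O)CO3)cc1NS(=O)(=O)c1ccc(F)cc1`) gives > 40000 nM, also a limit. So far the series is marked by the limit of > 40000 nM in this assay, at which 2 of the 3 values shown sit. For the measured compounds named here, the one measured step is a step that the two limits leave unreadable from compound 1 to compound 2, so it offers no size to carry forward. Going by the values given here, compound 3 (`O=C1COc2ccc(-c3cccc(NS(=O)(=O)c4ccc(F)cc4)c3)cc2N1c1ccc(Cl)cc1`) gives a number, 32500 nM, but differs from compound 1 in more than one place, so it provides no clean step.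

Compound 4 (`O=C1COc2ccc(-c3cnc(Cl)c(NS(=O)(=O)c4ccc(F)cc4)c3)cc2N1c1ccccc1`) makes a single change to compound 1: phenyl in place of cyclohexyl on an amide-type nitrogen in a ring. Among the compounds with values here, no measured step covers phenyl in place of cyclohexyl on an amide-type nitrogen in a ring. Within the data shown here, the expectation of a weak compound rests on compound 3 at 32500 nM, the only numerical value so far. Little or no gain in potency is expected, with an estimated at least 1.1-fold lower number from compound 1 to compound 4 (0.05 log units; that floor lies within the scatter). For compound 4 the estimate is 35000 nM, with an expected range of 14000 nM to 40000 nM.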

Compound 4, half-maximal inhibitory concentration: 36900 nM
Compound 4: middle estimate off by 1.1-fold (0.02 log units), on the low side; measured number inside the range.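

At the amide-type nitrogen in the ring, phenyl in place of cyclohexyl turns a limit into a number in this assay, and the reading is an at least 1.0-fold lower number from compound 1 to compound 4 (0.03 log units; that floor lies within the scatter). The two groups have the same count of heavy atoms and neither has a hydrogen-bond donor or acceptor, so this pair sets a non-aromatic ring against an aromatic one, and the printed floor shows no gain beyond the scatter. The series is still marked by a limit of the assay: the limit of > 40000 nM in this assay, at which 2 of the 4 values shown sit.

Still open, as far as these compounds go, is whether an amine or a carboxylic acid on the phenyl ring of compound 4 would move the number. Also open, from the compounds shown here alone, is how a methyl group or a longer alkyl chain would read on the same nitrogen.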